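Methyl in Place of Hydroxy on a Saturated Ring Carbon

The compounds below may be only part of what the source reports. "The series", "measured", "known", "first", "only" and "open" are said of these compounds alone.

Of the compounds shown here, three built on one shared core have been measured in an assay on CHO-K1 cells for activation of DNA damage-inducible transcript 3 protein (Homo sapiens), read by a luciferase reporter; a lower number here means that less compound is needed, a higher number that more compound is needed for the effect. Compound 1 `O=C(Nc1ccc(S(=O)(=O)N2CCNCC2)cc1)c1ccc([N+](=O)[O-])o1` gives 26400 nM. Compound 2 `O=C(Nc1ccc(S(=O)(=O)N2CCC(O)CC2)cc1)c1ccc([N+](=O)[O-])o1` gives 2000 nM, and compound 3 `O=C(Nc1ccc(S(=O)(=O)N2CCC(Cl)CC2)cc1)c1ccc([N+](=O)[O-])o1` gives 800 nM. Compound 2 therefore holds the second highest of the three numbers: the step of a 13-fold lower number from compound 1 to compound 2 (1.12 log units; beyond the scatter) is large, the step of a 33-fold lower number from compound 1 to compound 3 (1.52 log units; beyond the scatter) is large, and the step of a 2.5-fold lower number from compound 2 to compound 3 (0.40 log units; beyond the scatter) is modest.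

The unmeasured compound 4 `CC1CCN(S(=O)(=O)c2ccc(NC(=O)c3ccc([N+](=O)[O-])o3)cc2)CC1` differs from compound 2 by methyl in place of hydroxy on a saturated ring carbon. Within the data shown here, the one measured step that exchanges the hydroxy on this same saturated ring carbon is a 2.5-fold lower number from compound 2 to compound 3 (0.40 log units; beyond the scatter), where chloro entered in its place and the number fell modestly. Because a 2.5-fold lower number from compound 2 to compound 3 (0.40 log units; beyond the scatter) was modest, a change of similar size in the same direction is expected here, and compound 4 is expected to show the step of a 2.0-fold lower number from compound 2 to compound 4 (0.30 log units; within the scatter) in this assay. Compound 4 is thus estimated at 1000 nM, with a likely range from 400 nM to 2500 nM.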

Compound 4, concentration for half-maximal activity: 700 nM
Compound 4: the middle estimate sits 1.4-fold (0.15 log units) above what was measured; measured number inside the range.
By their numbers in this assay, from the lowest: compounds 4 and 3 (each within the scatter of the next); then compound 2; then compound 1.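

In this assay, the step of a 2.9-fold lower number from compound 2 to compound 4 (0.46 log units; beyond the scatter) shows that the fall seen with chloro is not unique to chloro: methyl, which the count gives no hydrogen-bond donor or acceptor, also brings the number down from that of the hydroxy compound. Between the two replacements, the step of a 1.1-fold lower number from compound 3 to compound 4 (0.06 log units; within the scatter) leaves methyl and chloro level, so this assay does not separate them at this ring carbon. The step of a 38-fold lower number from compound 1 to compound 4 (1.58 log units; beyond the scatter) is large, as it was for the hydroxy and chloro compounds, so 4-methylpiperidin-1-yl also stands far from piperazin-1-yl on the sulfonyl sulfur.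

On these data alone, whether an ethyl group, an amine or a carboxylic acid on this ring carbon would keep the number near that of methyl and chloro remains open. No measurement at hand explains why methyl and chloro differ from hydroxy here.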